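The source may report more compounds than this note shows. Statements on the series, on what has been measured and on what is new or still open speak of the compounds shown alone.

The series shares the core of compound 1 `C=C[C@@](C)(/C=C/c1ccc(O)c(CO)c1)CCC=C(C)C`. In a functional assay on Raji cells (Homo sapiens) for cytotoxicity, with a stated time of 72 h (on this read-out lower numbers stand for an effect already at smaller amounts and higher numbers for an effect only at larger amounts of compound), compound 1 gives only a limit, > 26000 nM. Compound 2 `C=C[C@@](C)(/C=C/c1ccc(Nc2ccc(OC)c(OC)c2)cc1)CCC=C(C)C` likewise reaches only a limit in this assay, > 26000 nM. Compound 3 `C=C[C@@](C)(/C=C/c1ccc(Nc2ccc(OC)c(F)c2)cc1)CCC=C(C)C` also gives only a limit in this assay, > 26000 nM. Compound 3 thus stands at the limit shared by all measured values, (the limit of > 26000 nM in this assay, at which 3 of the 3 values shown sit), and the step that the two limits leave unreadable from compound 2 to compound 3 remains unreadable. Compound 4 `C=C[C@@](C)(/C=C/c1ccc(Nc2ccc(Cl)c(Cl)c2)cc1)CCC=C(C)C` differs from compound 3 by 3,4-dichlorophenyl in place of 3-fluoro-4-methoxyphenyl on a nitrogen on an aromatic ring. Among the compounds with values here, no measured step bears on this change with a readable size, and the values known give no direction in this assay. Compound 4 is estimated at 30000 nM, within 8000 nM to 100000 nM, an expected step that the limit leaves unreadable from compound 3 to compound 4 that most likely ends again at a limit.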

Compound 4, half-maximal effective concentration: > 26000 nM
Compound 4 was reported as a limit; the forecaster's own chance of this, stated with the estimate: 80%; the middle value does not contradict the limit.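

Compound 3 and compound 4 both end at a limit, so no size can be read for the step between them: the limit of > 26000 nM in this assay, at which 4 of the 4 values shown sit.

The compounds shown leave open whether any change on the shared core gives a readable value in this assay.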